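This account rests on a few compounds, and the source may have more. Where it says the series, first, only, none or still open, it means among the compounds named here.

Measured so far in a functional assay on MCF7 cells (Homo sapiens) for antiproliferative activity, read by MTT assay, with a stated time of 3 days; a higher number here means a weaker inhibitor, a lower number a stronger inhibitor: compound 1 `CCCCCCCCC#Cc1cn(C/C=C\CN2C(=O)c3ccccc3C2=O)c(=O)[nH]c1=O` gives 64000 nM; compound 2 `CCCCC#Cc1cn(C/C=C/CN2C(=O)c3ccccc3C2=O)c(=O)[nH]c1=O` gives 8800 nM; compound 3 `CCCCc1ccc(C#Cc2cn(C/C=C\CN3C(=O)c4ccccc4C3=O)c(=O)[nH]c2=O)cc1` gives 43000 nM.

Compound 3 sits second highest of the three numbers in this assay, close to compound 1 and well above compound 2. Compound 4 `Cc1ccc(C#Cc2cn(C/C=C\CN3C(=O)c4ccccc4C3=O)c(=O)[nH]c2=O)cc1` differs from compound 3 by hydrogen in place of propyl on a saturated chain carbon bound to an aromatic carbon. Within the data shown here, the only single-change step at hand is a 1.5-fold lower number from compound 1 to compound 3 (0.17 log units; within the scatter), which swaps one chain-like end group for another without moving the number beyond the scatter; no step shortens a chain on the 4-butylphenyl end, and compound 2 differs from the others in more than one place. A small step is therefore expected, a 1.2-fold lower number from compound 3 to compound 4 (0.09 log units; within the scatter), with no clear direction. Compound 4 is estimated at 35000 nM, range 10000 nM to 100000 nM.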

Compound 4, half-maximal inhibitory concentration: > 100000 nM
Compound 4: only a limit was reported (the forecaster's own chance of this, stated with the estimate: 15%); at least 2.8-fold (0.45 log units) between middle value and limit.
By their numbers in this assay, from the lowest: compound 2; then compounds 3 and 1 (each within the scatter of the next). At a limit, above all of these: compound 4.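

In this assay, hydrogen in place of propyl on a saturated chain carbon bound to an aromatic carbon gives an at least 2.3-fold higher number from compound 3 to compound 4 (0.36 log units; beyond the scatter), so this end group responds to a change in chain length, which the earlier swap of end groups did not show. The other step, an at least 1.5-fold higher number from compound 1 to compound 4 (0.19 log units; that floor lies within the scatter), does not separate 4-methylphenyl from octyl on the triple-bonded carbon. Compound 4 is reported only as a limit: the limit of > 100000 nM in this assay, at which 1 of the 4 values shown sits.

On these data alone, the size of the drop from 4-butylphenyl to 4-methylphenyl stays open. So does the response to an ethyl, a longer chain or an amine at this place.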